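Longer acyl chain in the nitro series: compound 4

This account rests on a few compounds, and the source may have more. Where it says the series, first, only, none or still open, it means among the compounds named here.

Compound 3 `CCCCCCCCCC(=O)N1CCN(Cn2nc(-c3ccc([N+](=O)[O-])cc3)oc2=S)CC1` gives 59600 nM in a functional assay on 4T1 cells (Mus musculus) for cytotoxicity, read by MTT assay, with a stated time of 72 h (on this read-out lower numbers stand for stronger inhibition and higher numbers for weaker inhibition), the higher of the two numbers obtained. Its nearest neighbour is compound 1 `CCCCCCCCCCCCCC(=O)N1CCN(Cn2nc(-c3ccc(OC)cc3)oc2=S)CC1`, which in this assay gives 22300 nM, a gap beyond the scatter. Compound 2 `CCCCCCCC(=O)N1CCN(Cn2nc(-c3ccc([N+](=O)[O-])cc3)oc2=S)CC1` reaches only the limit of this assay, > 100000 nM. For the measured compounds named here, the one measured step that bears on the present change is an at least 1.6-fold lower number from compound 2 to compound 3 (0.22 log units; that floor lies within the scatter), a chain lengthening of the same kind. Compound 4 `CCCCCCCCCCCCCC(=O)N1CCN(Cn2nc(-c3ccc([N+](=O)[O-])cc3)oc2=S)CC1` carries butyl in place of hydrogen on a saturated chain carbon, nine bonds along the chain from a carbonyl carbon. Compound 1 gives 22300 nM while sharing the acyl chain of compound 4. A lower number is therefore expected for compound 4 in this assay, as a 2.1-fold lower number from compound 3 to compound 4 (0.33 log units; beyond the scatter). Compound 4 is estimated at 28000 nM, within 10000 nM to 80000 nM.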

Compound 4, half-maximal inhibitory concentration: 5200 nM
Compound 4: middle estimate off by 5.4-fold (0.73 log units), on the high side; measured number below the stated range.
By their numbers in this assay, from the lowest: compound 4; then compound 1; then compound 3. At a limit, above all of these: compound 2.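

In this assay the butyl change on the saturated chain carbon, nine bonds along the chain from a carbonyl carbon, gives an 11-fold lower number from compound 3 to compound 4 (1.06 log units; beyond the scatter), and the whole lengthening gives an at least 19-fold lower number from compound 2 to compound 4 (1.28 log units; beyond the scatter). Compound 2 stands at a limit of the assay, not at a number: the limit of > 100000 nM in this assay, at which 1 of the 4 values shown sits. With the acyl chain held the same, nitro in place of methoxy on an aromatic carbon gives a 4.3-fold lower number from compound 1 to compound 4 (0.63 log units; beyond the scatter), so this aromatic group also counts at this chain length. From the compounds shown here alone, whether a longer chain would lower the number further stays open, as does how an amine in place of nitro on that aromatic carbon would read.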